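The compounds below may be only part of what the source reports. "The series", "measured", "known", "first", "only" and "open" are said of these compounds alone.

Of the compounds shown here, three that share one core have so far been tested in a functional assay on HepG2 cells (Homo sapiens) for cytotoxicity, read by MTT assay, with a stated time of 48 h; a higher number here means a weaker inhibitor, a lower number a stronger inhibitor. Compound 1 `Cc1nnc(SCc2ccccc2)n1N1C(=O)c2ccccc2C1=O` is the plainest of them. In this assay compound 1 gives no number, only a limit, > 200000 nM. Compound 2 `Cc1ccc(C(=O)CSc2nnc(C)n2N2C(=O)c3ccccc3C2=O)cc1` carries a (4-methylphenyl)carbonyl where compound 1 carries a phenyl on a saturated chain carbon bound to a sulfur. In this assay compound 2 likewise reaches only a limit, > 200000 nM. Compound 3 `Cc1nnc(SCc2ccccc2Cl)n1N1C(=O)c2ccccc2C1=O` has a chloro in place of a hydrogen on an aromatic carbon. In this assay compound 3 too stops at a limit, > 200000 nM. The three steps among them, a step that the two limits leave unreadable from compound 1 to compound 2, a step that the two limits leave unreadable from compound 1 to compound 3 and a step that the two limits leave unreadable from compound 2 to compound 3, have no readable size because the limit of > 200000 nM in this assay, at which 3 of the 3 values shown sit, hides whatever difference there may be. Compound 2 therefore stands nowhere in particular: it sits at the same limit as its two neighbours.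

Compound 4 `CCCc1nnc(SCC(=O)c2ccc(C)cc2)n1N1C(=O)c2ccccc2C1=O` is not yet measured. Among the compounds with values here, it differs from compound 2 by ethyl in place of hydrogen on a saturated chain carbon bound to an aromatic carbon, and no measured step speaks to such a change. Nothing in the three limits gives a reason to expect a readable step in this assay. Compound 4 is accordingly expected to sit near 200000 nM, in a range from 50000 nM to 600000 nM, and the expected step of a number no higher from compound 2 to compound 4 (the limit leaves the size open) is none beyond the scatter.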

Compound 4, half-maximal inhibitory concentration: > 200000 nM
Compound 4: no number, only a limit; the forecaster's own chance of this, stated with the estimate: 85%; the middle value sits exactly at the limit.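

In this assay compound 4 also gives only a limit, > 200000 nM. Within the data shown here, no step from compound 2 to compound 4 can be read, because both stop at the same limit: the limit of > 200000 nM in this assay, at which 4 of the 4 values shown sit. The compounds shown leave open whether any of the changes among them, including ethyl in place of hydrogen, alters the result in this assay.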